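Methylsulfanyl for fluoro on the cinnamamide aryl ring

The compounds below may be only part of what the source reports. "The series", "measured", "known", "first", "only" and "open" are said of these compounds alone.

Measured compounds:
compound 1 `Nc1cc(C2CCCC2)nc2ccc(NC(=O)/C=C/c3ccc(C(F)(F)F)cc3)cc12` — 68 nM
compound 2 `CCCc1cc(N)c2cc(NC(=O)/C=C/c3ccc(F)cc3)ccc2n1` — 200 nM
compound 3 `Nc1cc(C2CCC2)nc2ccc(NC(=O)/C=C/c3ccc(C(F)(F)F)cc3)cc12` — 250 nM

In a functional assay on HEK293 cells for activation of melanin-concentrating hormone receptor 1 (Homo sapiens), read by inositol phosphate accumulation (a higher number here means that more compound is needed for the effect, a lower number that less compound is needed), compound 2 stands second highest of the three numbers. Its value and that of compound 3 lie within the scatter of one another, so no order between them is claimed. Compound 1 gives a clearly lower number than compound 2, beyond the scatter.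

Compound 4 `CCCc1cc(N)c2cc(NC(=O)/C=C/c3ccc(SC)cc3)ccc2n1` is not yet measured. It differs from compound 2 by methylsulfanyl in place of fluoro on an aromatic carbon; cut one bond further out, the change reads 4-fluorophenyl to 4-(methylsulfanyl)phenyl.

Going by the values given here, the only measured single-place step, a 3.7-fold higher number from compound 1 to compound 3 (0.57 log units; beyond the scatter), concerns the ring on the other side of the core and does not touch the cinnamamide aryl ring. Among the compounds with values here, no measured pair reports a change at the position varied here, so the step is uncharted in this set.

With nothing to anchor the direction, compound 4 is expected to stay close to compound 2, with the step of no change at the digits printed from compound 2 to compound 4 (within the scatter) estimated as not beyond the scatter. The estimate for compound 4 in this assay is 200 nM, with a range of 70 nM to 600 nM.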

Compound 4, half-maximal effective concentration: 71 nM
The estimate for compound 4 lay 2.8-fold (0.45 log units) above the measured number; the measured number falls inside the stated range.
By their numbers in this assay, from the lowest: compounds 1 and 4 (each within the scatter of the next); then compounds 2 and 3 (each within the scatter of the next).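

In this assay the cinnamamide aryl ring now has its first measured step, a 2.8-fold lower number from compound 2 to compound 4 (0.45 log units; beyond the scatter) with methylsulfanyl in place of fluoro, so the group at this position does affect the read-out. The entering group has one more heavy atom and one more hydrogen-bond acceptor by count, and it is accepted on this aromatic carbon, para to a large group, with the rest of compound 2 unchanged. No measurement at hand bears on the origin of this step.

A single step cannot separate the role of the sulfur from that of the added methyl; methoxy or the longer ethylsulfanyl would address this. From the compounds shown here alone, whether the same change holds alongside the cyclopentyl and cyclobutyl groups of compound 1 and compound 3, which carry trifluoromethyl on this ring, also remains open.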